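Compound 1 to compound 4: trifluoromethyl for bromo

The source may hold more compounds than are shown below. What is called first, only, known or untested is meant among the compounds shown, and "the series" means these compounds.

Compound 1 `C=C1C[C@]23C[C@@]1(O)CC[C@H]2c1ccc(OS(=O)(=O)c2ccc(C)cc2)c(C)c1[C@@H]3Cn1cc(-c2ccc(Br)cc2)nn1` was run in a functional assay on SW480 cells (Homo sapiens) for cytotoxicity, read by MTT assay, with a stated time of 4 days; a lower number here means a stronger inhibitor, a higher number a weaker inhibitor. In this assay compound 1 gives > 20000 nM, which is a limit of the assay and not a number. Two related compounds are known only as limits as well. Compound 2 `Cc1ccc(S(=O)(=O)Oc2ccc3c(c2C)[C@H](Cn2cc(-c4ccc(C(F)(F)F)cc4)nn2)[C@@]24CC(=O)[C@@](C)(CC[C@@H]32)C4)cc1` gives > 20000 nM in this assay, a limit. Compound 3 `Cc1c(O)ccc2c1[C@H](Cn1cc(-c3ccccn3)nn1)[C@@]13CC(=O)[C@@](C)(CC[C@@H]21)C3` gives > 20000 nM in this assay, again a limit. Compound 1 thus cannot be placed in any order among these; every value known so far sits at the limit of > 20000 nM in this assay, at which 3 of the 3 values shown sit, and no step between two measured compounds can be drawn.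

Compound 4 `C=C1C[C@]23C[C@@]1(O)CC[C@H]2c1ccc(OS(=O)(=O)c2ccc(C)cc2)c(C)c1[C@@H]3Cn1cc(-c2ccc(C(F)(F)F)cc2)nn1` has not yet been measured. It differs from compound 1 by trifluoromethyl in place of bromo on an aromatic carbon. Compound 2, which carries the same 4-(trifluoromethyl)phenyl group on a differently built core, also gives only a limit in this assay. The step that the limit leaves unreadable from compound 1 to compound 4 is therefore expected to lie within the scatter, in no direction. Compound 4 is expected at 30000 nM, within 10000 nM to 100000 nM, and most likely to be reported as a limit once more.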

Compound 4, half-maximal inhibitory concentration: > 20000 nM
Compound 4 was reported as a limit; the forecaster's own chance of this, stated with the estimate: 85%; the middle value lies beyond the limit too.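

In this assay compound 4 gives > 20000 nM as a limit of the assay and not a number. Compound 1 is also known only as a limit, so no step between compound 1 and compound 4 can be read: the limit of > 20000 nM in this assay, at which 4 of the 4 values shown sit.

On these data alone, whether 4-bromophenyl and 4-(trifluoromethyl)phenyl differ at all on this shared core remains open.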